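A few compounds are considered here, and "the series" means these few. Any claim that something is new, unique, unknown or untested is made for them only; others in the source may bear on it.

Measured compounds in an assay on isolated protein for binding affinity to Equilibrative nucleoside transporter 1 (Homo sapiens); on this read-out higher numbers stand for weaker inhibition and lower numbers for stronger inhibition:
- compound 1, `OC[C@H]1O[C@@H](n2cnc3c(OCc4ccccc4)ncnc32)[C@H](O)[C@@H]1O`: 2090 nM
- compound 2, `OC[C@H]1O[C@@H](n2cnc3c(SC4CCCCC4)ncnc32)[C@H](O)[C@@H]1O`: 6310 nM
- compound 3, `CCSc1ncnc2c1ncn2[C@@H]1O[C@H](CO)[C@@H](O)[C@H]1O`: 57500 nM

Compound 3 holds the highest number of the three; the nearest is compound 2 (a 9.1-fold higher number from compound 2 to compound 3 (0.96 log units; beyond the scatter)), the furthest compound 1 (a 28-fold higher number from compound 1 to compound 3 (1.44 log units; beyond the scatter)). Both steps into compound 3 lie beyond the scatter, so compound 3 is the weakest of the measured set in this assay.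

Compound 4, `CC(C)c1ccc(CSc2ncnc3c2ncn3[C@@H]2O[C@H](CO)[C@@H](O)[C@H]2O)cc1`, is reached from compound 3 by the change (4-isopropylphenyl in place of methyl on a saturated chain carbon bound to a sulfur), keeping the sulfur attachment.

Within the data shown here, two measured steps bear on it. The step of a 9.1-fold higher number from compound 2 to compound 3 (0.96 log units; beyond the scatter) shows that shrinking the group on sulfur from cyclohexyl to ethyl raised the number; the reverse direction, enlarging the group, is what compound 4 does. The step of a 28-fold higher number from compound 1 to compound 3 (1.44 log units; beyond the scatter) shows that a benzyl-type substituent with an oxygen link gave the lowest number of the set. Compound 4 combines a benzyl-type group with the sulfur link and adds isopropyl on the ring, a combination not measured here, so the expected drop is set between those two steps rather than at either extreme.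

The expected step is a 38-fold lower number from compound 3 to compound 4 (1.58 log units; beyond the scatter), a marked fall in the number. Compound 4 is therefore estimated at 1500 nM, with a range of 300 nM to 7000 nM.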

Compound 4, half-maximal inhibitory concentration: 4790 nM
Beside the measured number, compound 4's estimate is 3.2-fold (0.50 log units) below it, and the stated range covers the measured number.
By their numbers in this assay, from the lowest: compound 1; then compounds 4 and 2 (each within the scatter of the next); then compound 3.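

In this assay, among these compounds, the position on sulfur accepts a much larger group than the ethyl of compound 3: the chain extended with 4-isopropylphenyl gives a 12-fold lower number from compound 3 to compound 4 (1.08 log units; beyond the scatter) as a large step, and this is the first aromatic ring to be read on a sulfur link. Compound 4 at 4790 nM and compound 2 at 6310 nM lie within the scatter of each other, so at this position the 4-isopropylphenyl-bearing chain and the cyclohexyl cannot be told apart in this read-out, although both stand clear of the ethyl. Nothing measured here accounts for why either large group on sulfur gives a lower number than ethyl.

From the compounds shown here alone, what the isopropyl contributes on its own stays open, since a plain benzyl group on the sulfur would be needed to separate it from the phenyl ring and the added chain carbon. Also open, going by these compounds, is how the number responds when an amine or a carboxylic acid takes the place of the isopropyl on that ring.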